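A few compounds are considered here, and "the series" means these few. Any claim that something is new, unique, unknown or untested is made for them only; others in the source may bear on it.

Of the compounds shown here, two have been tested in an ADME assay on MDBK cells (Bos taurus) for cytotoxicity; a higher number here means that more compound is tolerated, a lower number that less compound is tolerated. Compound 1, `Cc1ccn(Cc2c(F)cccc2F)c2nc(-c3c(F)cccc3F)nc1-2`, reaches the assay limit of > 100000 nM in this assay. Compound 2, `Fc1cccc(Cn2ccc3nc(-c4ccccc4)nc-3c2)c1`, likewise reaches the assay limit of > 100000 nM in this assay. Where compound 2 stands is thus known only as a limit, and both numbers shown sit at the limit of > 100000 nM in this assay, at which 2 of the 2 values shown sit. Compound 3, `N#Cc1ccc(Cn2ccc3nc(-c4ccccc4)nc-3c2)cc1`, differs from compound 2 in one place: 4-cyanophenyl in place of 3-fluorophenyl on a saturated chain carbon bound to an aromatic nitrogen. Within the data shown here, no measured step is available for this kind of change, so its size cannot be read from any pair of measured compounds. Because compound 1 and compound 2 both stand at the limit of > 100000 nM in this assay, at which 2 of the 2 values shown sit, compound 3 is expected to be tolerated to a similar degree. The expected step of a number no higher from compound 2 to compound 3 (the limit leaves the size open) is none beyond the scatter. The estimate for compound 3 in this assay is 100000 nM, with a range from 30000 nM to 300000 nM.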

Compound 3, half-maximal cytotoxic concentration: > 100000 nM
Compound 3 gave a limit, no number; the forecaster's own chance of this, stated with the estimate: 80%; the middle value sits exactly at the limit.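

Among these compounds, compound 2 and compound 3 both stand at a limit in this assay, so no step between them can be read. The compounds shown leave open the concentration at which any of them becomes cytotoxic, since all sit at one value: the limit of > 100000 nM in this assay, at which 3 of the 3 values shown sit.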